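Shifting fluorine on the aryl group of compound 2

The source may hold more compounds than are shown below. What is called first, only, known or untested is meant among the compounds shown, and "the series" means these compounds.

Compound 2 `CCOC(=O)C1=C(C)NC(C)=C(C(=O)OCC)C1c1c(-c2ccccc2F)nc2sccn12` stands highest of the three numbers: in an ADME assay on Left cardiac atrium (Cavia porcellus) (on this read-out lower numbers stand for an effect already at smaller amounts and higher numbers for an effect only at larger amounts of compound), compound 2 gives 5150 nM. Compound 1 `CCOC(=O)C1=C(C)NC(C)=C(C(=O)OCC)C1c1c(-c2ccc(OC(F)(F)F)cc2)nc2sc(Br)cn12` gives 93 nM in this assay, and compound 3 `CCOC(=O)C1=C(C)NC(C)=C(C(=O)OCC)C1c1c(-c2ccc(F)cc2)nc2sc(Cl)cn12` gives 49 nM; both gaps to compound 2 lie beyond the scatter. Compound 4 `CCOC(=O)C1=C(C)NC(C)=C(C(=O)OCC)C1c1c(-c2ccc(F)c(F)c2)nc2sccn12` differs from compound 2 by 3,4-difluorophenyl in place of 2-fluorophenyl on an aromatic carbon. Among the measured compounds shown here, no measured pair isolates this change, and compounds 1 and 3 differ from compound 2 in more than one place, so the expectation rests loosely on them. Compound 4 is expected to give a lower number than compound 2, a step of a 5.7-fold lower number from compound 2 to compound 4 (0.76 log units; beyond the scatter), with wide uncertainty. The estimate for compound 4 is 900 nM, within 150 nM to 4500 nM.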

Compound 4, half-maximal effective concentration: 21 nM
Compound 4: the middle estimate sits 43-fold (1.63 log units) above what was measured; the measured number lies below the stated range.
By their numbers in this assay, from the lowest: compound 4; then compounds 3 and 1 (each within the scatter of the next); then compound 2.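

Putting 3,4-difluorophenyl in place of 2-fluorophenyl on this aromatic carbon gives a 250-fold lower number from compound 2 to compound 4 (2.39 log units; beyond the scatter) in this assay, so a change at this position alone, with the rest of the molecule the same, moves the read-out far beyond the scatter. Compound 1 and compound 3 could not show this, as each differs from compound 2 in more than one place. No evidence bearing on the cause of this step is available. Going by these compounds, it remains open whether the step comes from the added fluorine or from the loss of the 2-fluorophenyl arrangement, and how a phenyl ring carrying a methoxy group or an amine would read.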